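Swapping 3,4-Dichlorophenyl for 3-Bromophenyl

A few compounds are considered here, and "the series" means these few. Any claim that something is new, unique, unknown or untested is made for them only; others in the source may bear on it.

In a functional assay on HCT-116 cells (Homo sapiens) for antiproliferative activity, read by MTT assay, with a stated time of 72 h (on this read-out lower numbers stand for stronger inhibition and higher numbers for weaker inhibition), compound 1 `NC1=NC2(CCOCC2)N(OCCCOc2ccccc2)C(N)=N1` gives 6010 nM. Compound 2 `NC1=NC2(CCOCC2)N(OCCCOc2ccc(Cl)c(Cl)c2)C(N)=N1` gives 90 nM, the lower of the two numbers and so the stronger inhibition. Among the compounds with values here, the one measured step, a 67-fold lower number from compound 1 to compound 2 (1.82 log units; beyond the scatter), comes with 3,4-dichlorophenyl in place of phenyl on an oxygen on a saturated carbon. Compound 3 `NC1=NC2(CCOCC2)N(OCCCOc2cccc(Br)c2)C(N)=N1` has not yet been measured. It carries 3-bromophenyl in place of 3,4-dichlorophenyl at that same place: 3-bromophenyl in place of 3,4-dichlorophenyl on an oxygen on a saturated carbon. Its ring keeps a bromine, unlike the plain phenyl of compound 1, but has no chlorine. Within the data shown here, the measured step involves no bromine, so it shows only that changing this ring can move the number greatly. The expected change in this assay is a moderate rise, a 2.8-fold higher number from compound 2 to compound 3 (0.44 log units; beyond the scatter), far smaller than the measured step. For compound 3, the estimated value is 250 nM, with an expected range from 70 nM to 900 nM.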

Compound 3, half-maximal inhibitory concentration: 40 nM
Estimate against measurement, compound 3: 6.3-fold (0.80 log units) above; measured number below the stated range.
By their numbers in this assay, from the lowest: compound 3; then compound 2; then compound 1.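

Replacing 3,4-dichlorophenyl with 3-bromophenyl in this assay gives a 2.3-fold lower number from compound 2 to compound 3 (0.35 log units; beyond the scatter), so two chlorines are not required on this ring for a low number. Against the plain phenyl, a single bromo on an aromatic carbon gives a 150-fold lower number from compound 1 to compound 3 (2.18 log units; beyond the scatter), which shows that one added atom can account for a very large change at this place. Within the data shown here, nothing available here explains why these ring changes move the number so far.

From the compounds shown here alone, it remains open whether a single chlorine or fluorine would serve as well as the bromine, or whether bromine itself matters. The effect of an amine or a carboxylic acid on this ring is also unknown, as is the effect of a longer chain between the oxygen and the ring.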